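The source may report more compounds than this note shows. Statements on the series, on what has been measured and on what is new or still open speak of the compounds shown alone.

Measured compounds:
- compound 1 `CN1CCN(CCCOc2cccc3nc(Nc4ccc(Cl)c(C(F)(F)F)c4)ccc23)CC1`, in a functional assay on RXF 393 cells (Homo sapiens) for inhibition, read by sulforhodamine B assay, with a stated time of 48 h (a lower number here means a stronger inhibitor of growth, a higher number a weaker inhibitor of growth), compound 1 gives 1630 nM
- compound 2 `CN1CCN(CCCOc2cccc3nc(Nc4ccc(Cl)c(F)c4)ccc23)CC1`, compound 2 gives 1960 nM
- compound 3 `CN1CCN(CCCOc2cccc3nc(Nc4ccc(F)c(F)c4)ccc23)CC1`, compound 3 gives 2110 nM

Compound 3 has the highest of the three numbers; its nearest neighbour is compound 2 and its furthest is compound 1, and both gaps are within the scatter, so the three stand together. The next compound, compound 4 `CN1CCN(CCCOc2cccc3nc(Nc4cc(Cl)cc(Cl)c4)ccc23)CC1`, differs from compound 3 by 3,5-dichlorophenyl in place of 3,4-difluorophenyl on a nitrogen on an aromatic ring. Every step measured so far touches substituents on the same phenyl ring: fluoro for chloro gave a 1.1-fold higher number from compound 2 to compound 3 (0.03 log units; within the scatter), fluoro for trifluoromethyl gave a 1.2-fold higher number from compound 1 to compound 2 (0.08 log units; within the scatter), and the full exchange of the ring gave a 1.3-fold higher number from compound 1 to compound 3 (0.11 log units; within the scatter), none beyond the scatter. Among the measured compounds shown here, no measured pair swaps the substitution pattern itself, so the move to a 3,5-dichlorophenyl rests on the general flatness seen across compounds 1 to 3. On that basis compound 4 is expected to show no step beyond the scatter, a 1.1-fold lower number from compound 3 to compound 4 (0.02 log units; within the scatter). The estimate for compound 4 in this assay is 2000 nM, with a range from 800 nM to 5000 nM.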

Compound 4, concentration for 50% growth inhibition: 1670 nM
Beside the measured number, compound 4's estimate is 1.2-fold (0.08 log units) above it; measured number inside the range.
By their numbers in this assay, from the lowest: compounds 1, 4, 2 and 3 (each within the scatter of the next).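

In this assay, among the compounds shown here, the first change in the arrangement of halogens on this phenyl ring stays within the scatter against all three earlier compounds (a 1.3-fold lower number from compound 3 to compound 4 (0.10 log units; within the scatter)) (a 1.2-fold lower number from compound 2 to compound 4 (0.07 log units; within the scatter)) (a 1.0-fold higher number from compound 1 to compound 4 (0.01 log units; within the scatter)). Among these four compounds, the aryl group on this nitrogen therefore accepts a change in halogen arrangement as well as in halogen identity, with no separation in the numbers. Nothing available explains this flatness.

On these data alone, all four compounds carry only halogen-bearing or trifluoromethyl-bearing phenyl groups on this nitrogen, so it remains open whether an unsubstituted phenyl, a methoxy group, a carboxylic acid or an amine there would move the number beyond the scatter. Also open, as far as these compounds go, is whether a longer chain to the methylpiperazine, or a morpholine in its place, would do so.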